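A few compounds are considered here, and "the series" means these few. Any claim that something is new, unique, unknown or untested is made for them only; others in the source may bear on it.

Two compounds share one core and differ only in the ring attached to the carbonyl carbon. Compound 1 `COc1ccc(/C=C/c2cc(OC)cc(OC)c2/C=C/C(=O)c2ccc(Cl)c(Cl)c2)cc1` carries a 3,4-dichlorophenyl there, and in a functional assay on HepG2 cells (Homo sapiens) for antiproliferative activity, read by MTT assay, with a stated time of 48 h (a lower number here means a stronger inhibitor, a higher number a weaker inhibitor), compound 1 gives 10.8 ug/mL. Compound 2 `COc1ccc(/C=C/c2cc(OC)cc(OC)c2/C=C/C(=O)c2cccc(Br)c2)cc1` carries a 3-bromophenyl instead, and in this assay compound 2 gives 13 ug/mL. The step of a 1.2-fold higher number from compound 1 to compound 2 (0.08 log units; within the scatter) means these two numbers cannot be told apart, so compound 2 stands alongside compound 1 rather than apart from it. Compound 3 `COc1ccc(/C=C/c2cc(OC)cc(OC)c2/C=C/C(=O)c2ccc(Br)cc2)cc1` has not yet been measured; its change from compound 2 is 4-bromophenyl in place of 3-bromophenyl on a carbonyl carbon. Among the compounds with values here, the only step that bears on it, a 1.2-fold higher number from compound 1 to compound 2 (0.08 log units; within the scatter), also swapped the ring on the carbonyl carbon and stayed within the scatter, so the expected step in this assay is none beyond the scatter, no change at the digits printed from compound 2 to compound 3 (within the scatter). Compound 3 is therefore estimated at 13 ug/mL, with a range from 6.5 ug/mL to 26 ug/mL.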

Compound 3, half-maximal inhibitory concentration: 12.9 ug/mL
Compound 3: middle estimate off by 1.0-fold (0.00 log units), on the high side; low and high end bracket the measured number.
By their numbers in this assay, from the lowest: compounds 1, 3 and 2 (each within the scatter of the next).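

Swapping 3-bromophenyl for 4-bromophenyl on the carbonyl carbon, which keeps the same atoms but joins them differently, gives a 1.0-fold lower number from compound 2 to compound 3 (0.00 log units; within the scatter) in this assay and so shows that, for this pair, where the bromine sits on the ring makes no readable difference. The step with 4-bromophenyl in place of 3,4-dichlorophenyl gives a 1.2-fold higher number from compound 1 to compound 3 (0.08 log units; within the scatter) and is also unreadable, so all three rings at this position now stand level, each within the scatter of the others. Nothing measured here explains why these three rings cannot be told apart.

From the compounds shown here alone, all three rings carry only chlorine or bromine, so it remains open whether the number would hold with an amine or a carboxylic acid on the ring. A plain phenyl with no added group is also untested in what is shown here.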